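This account rests on a few compounds, and the source may have more. Where it says the series, first, only, none or still open, it means among the compounds named here.

Measured in an ADME assay on HepG2 2.2.15 cells (Homo sapiens) for cytotoxicity; a higher number here means that more compound is tolerated, a lower number that less compound is tolerated:
compound 1 `CC(C)(C)OC(=O)Nc1ncc(C(Oc2cccc(C#N)c2)c2ccc(Cl)cc2)s1` — > 50000 nM
compound 2 `O=C(Nc1ncc(C(Oc2ccc3cc(Br)ccc3c2)c2ccc(Cl)cc2)s1)C1CC1` — "not toxic" (no number reported)
compound 3 `CCCCCC(=O)Nc1ncc(C(Oc2ccc3cc(Br)ccc3c2)c2ccc(Cl)cc2)s1` — > 50000 nM

The value of compound 1 is a limit of this assay, not a number. For compound 2 only the word "not toxic" is given, without a number. The value of compound 3 is likewise a limit of this assay. Compound 3 thus stands at the limit of > 50000 nM in this assay, at which 2 of the 3 values shown sit, together with compound 1, while compound 2 stands beside them without a figure. Going by the values given here, no pair of measured compounds differs in a single place, so no measured step size is known for this series, and the three entries show only that none of the compounds was found toxic within the tested range.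

Compound 4 `O=C(Nc1ncc(C(Oc2ccc3cc(Br)ccc3c2)c2ccc(Cl)cc2)s1)c1cc(F)c(F)cc1F` is the next compound for this assay. It differs from compound 3 by 2,4,5-trifluorophenyl in place of pentyl on a carbonyl carbon. A step beyond the scatter is not expected here, because compound 3 sits at the limit of > 50000 nM in this assay, at which 2 of the 3 values shown sit, and compound 1 sits there as well. The step from compound 3 to compound 4 is therefore estimated as a number no higher from compound 3 to compound 4 (the limit leaves the size open). Compound 4 is expected to give 50000 nM, with a range from 15000 nM to 100000 nM, most likely reported again only as a limit.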

Compound 4, half-maximal cytotoxic concentration: "not toxic" (no number reported)
Nothing numeric was reported for compound 4; no gap can be computed for the estimate.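

In this assay no step can be read between compound 3 and compound 4: compound 4 is entered only as not toxic, without a figure, and compound 3 gives > 50000 nM, which is a limit. The compounds shown leave open the concentration at which any of them becomes cytotoxic, and whether 2,4,5-trifluorophenyl in place of pentyl changes it.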